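The source may hold more compounds than are shown below. What is called first, only, known or untested is meant among the compounds shown, and "the series" means these compounds.

Measured in a functional assay on HepG2 cells (Homo sapiens) for antiproliferative activity, read by sulforhodamine B assay, with a stated time of 48 h; on this read-out lower numbers stand for stronger inhibition and higher numbers for weaker inhibition:
- compound 1 `COc1cccc(/C=C/C(=O)/C=C(O)/C=C/c2cccc(OC)c2OC)c1OC`: 12900 nM
- compound 2 `COc1ccc(OC)c(/C=C/C(=O)/C=C(O)/C=C/c2cc(OC)ccc2OC)c1`: 5560 nM
- compound 3 `COc1cccc(/C=C/C(=O)C(=Cc2ccc(F)cc2)C(=O)/C=C/c2cccc(OC)c2OC)c1OC`: 580 nM

Of these three, compound 3 stands lowest at 580 nM, and both of the other numbers lie higher by more than the usual scatter. The nearest neighbour is compound 2 at 5560 nM, and furthest away is compound 1 at 12900 nM. Among the compounds with values here, compound 3 is also the only measured compound with an aryl group on a double-bonded chain carbon bound to a double-bonded chain carbon.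

The next compound, compound 4 `COc1cccc(/C=C/C(=O)C(=Cc2cc(OC)c(OC)c(OC)c2)C(=O)/C=C/c2cccc(OC)c2OC)c1OC`, changes exactly that group: 3,4,5-trimethoxyphenyl stands in place of 4-fluorophenyl (3,4,5-trimethoxyphenyl in place of 4-fluorophenyl on a double-bonded chain carbon bound to a double-bonded chain carbon). Within the data shown here, no measured pair shows what exchanging this group does, so the expectation starts from compound 3 at 580 nM and carries wide uncertainty. The larger group could plausibly move the number either way, with a slight rise judged a little more likely. The expected step, a 1.2-fold higher number from compound 3 to compound 4 (0.08 log units; within the scatter), is small and upward, and no change beyond the scatter is anticipated. For compound 4 the estimated value is 700 nM, with an expected range from 200 nM to 2500 nM.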

Compound 4, half-maximal inhibitory concentration: 220 nM
Compound 4: the middle estimate sits 3.2-fold (0.50 log units) above what was measured; the measured number falls inside the stated range.
By their numbers in this assay, from the lowest: compound 4; then compound 3; then compound 2; then compound 1.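

In this assay, placing 3,4,5-trimethoxyphenyl in place of 4-fluorophenyl on a double-bonded chain carbon bound to a double-bonded chain carbon gives a 2.6-fold lower number from compound 3 to compound 4 (0.42 log units; beyond the scatter), the first measured sign that the choice of aryl group at this place moves the number. The entering group is the larger one, with 12 heavy atoms against 7 and 3 hydrogen-bond acceptors against 0, and in this one pair the number falls rather than rises, so this place tolerates the larger group without a loss in this read-out. No measurement at hand speaks to what lies behind this step.

The compounds shown leave open whether the lower number needs all three methoxy groups, or whether a single 4-methoxyphenyl or an unsubstituted phenyl at this place would give a similar value. They also leave open how an amine or a carboxylic acid on this aryl group would read, and whether the step seen here would hold on a core carrying different methoxy groups on its outer rings.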